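Moving one nitrogen in a side chain

This account rests on a few compounds, and the source may have more. Where it says the series, first, only, none or still open, it means among the compounds named here.

Compound 1 `CCCNC(=O)Nc1cccc2c1CN(C)CC2c1ccccc1` gives > 80 mg/kg
Compound 2 `CCOC(=O)Nc1cccc2c1CN(C)CC2c1ccc(Cl)cc1` gives 4.8 mg/kg

In a functional assay on the whole organism for inhibition, with Mus musculus as the target (on this read-out higher numbers stand for an effect only at larger amounts of compound and lower numbers for an effect already at smaller amounts), compound 1 is known only as a limit (> 80 mg/kg). Compound 3 `CCNCC(=O)Nc1cccc2c1CN(C)CC2c1ccccc1` keeps the atoms of compound 1 but joins them differently, with (ethylamino)methyl in place of propylamino on a carbonyl carbon. Going by the values given here, no measured pair isolates this change, so any expectation is loose. A move toward lower numbers is expected, as compound 2 (4.8 mg/kg) shows that a related structure can act at smaller amounts. The estimated step is an at least 4.0-fold lower number from compound 1 to compound 3 (0.60 log units; beyond the scatter) and it remains uncertain. Compound 3 is expected at 20 mg/kg (estimated range 4 mg/kg to 90 mg/kg).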

Compound 3, dose for half-maximal effect: 47 mg/kg
The estimate for compound 3 lay 2.4-fold (0.37 log units) below the measured number, within the range that was stated.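

With the same atoms joined differently, (ethylamino)methyl in place of propylamino on a carbonyl carbon gives a measured number in this assay rather than a limit, and the change reads as an at least 1.7-fold lower number from compound 1 to compound 3 (0.23 log units; that floor lies within the scatter). This shows that the placing of the nitrogen in this side chain alone can be enough to bring a number within reach of the read-out. Compound 1 is known only as a limit, so the true size of the step stays open: the limit of > 80 mg/kg in this assay, at which 1 of the 3 values shown sits.

The compounds shown leave open how a dimethylamino group, a piperidine or a longer chain would read in place of (ethylamino)methyl.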